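Solubility limits and the fluoro to bromo change

The source may report more compounds than this note shows. Statements on the series, on what has been measured and on what is new or still open speak of the compounds shown alone.

Measured so far in a physicochemical assay for solubility; on this read-out lower numbers stand for lower solubility and higher numbers for higher solubility:
compound 1 `COc1cc(/C=C(/SCc2ccc(Br)cc2)C(=O)c2ccc(C(=O)O)cc2)ccc1F` gives < 1000 ug/mL as a limit
compound 2 `O=C(O)c1ccc(C(=O)/C(=C\c2ccc(Cl)c([N+](=O)[O-])c2)SCc2ccc(Br)cc2)cc1` gives < 1000 ug/mL as a limit
compound 3 `O=C(O)c1ccc(C(=O)/C(=C\c2ccc(Br)c([N+](=O)[O-])c2)SCc2ccc(F)cc2)cc1` gives < 1000 ug/mL as a limit

Compound 3 stands at < 1000 ug/mL as a limit. Among the compounds with values here, the series so far offers only the limit of < 1000 ug/mL in this assay, at which 3 of the 3 values shown sit, and so gives no number against which to place compound 3. The next compound is compound 4 `O=C(O)c1ccc(C(=O)/C(=C\c2ccc(Br)c([N+](=O)[O-])c2)SCc2ccc(Br)cc2)cc1` with bromo in place of fluoro on an aromatic carbon in the change from 4-fluorobenzyl to 4-bromobenzyl. Within the data shown here, the sole measured step is a step that the two limits leave unreadable from compound 1 to compound 2 and it concerns a different group, so it offers no size to carry over. No step beyond the scatter is expected in this assay and no direction is expected either. The expected step is a step that the limit leaves unreadable from compound 3 to compound 4 and this is an estimate made without any readable step behind it. A limit is again the likeliest expected report for compound 4. For compound 4 the estimated value is 300 ug/mL with 50 ug/mL to 1000 ug/mL as the expected range.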

Compound 4, solubility: < 1000 ug/mL
Compound 4: a limit, no number (the forecaster's own chance of this, stated with the estimate: 90%); the middle value lies beyond the limit too.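

In this assay compound 4 gives < 1000 ug/mL, a limit, so no step linking it to compound 1, compound 2 or compound 3 can be read: the limit of < 1000 ug/mL in this assay, at which 4 of the 4 values shown sit.

The compounds shown leave open whether bromo in place of fluoro, or any other change here, moves this read-out at all.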